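One Chlorine Fewer: What to Expect for Compound 3

This account rests on a few compounds, and the source may have more. Where it says the series, first, only, none or still open, it means among the compounds named here.

Compound 1 `ClCc1ccccc1Cn1cnc2c(Cl)nc(Cl)nc21`: 6450 nM
Compound 2 `ClCc1ccc(Cn2cnc3nc(Cl)nc(Cl)c32)cc1`: 5750 nM

In a functional assay on MDA-MB-435 cells (Homo sapiens) for cytotoxicity, read by sulforhodamine B assay, with a stated time of 48 h (on this read-out lower numbers stand for higher toxicity in this test and higher numbers for lower toxicity in this test), compound 1 gives 6450 nM, and compound 2 gives 5750 nM. Compound 2 carries the lower of the two numbers, but its gap to compound 1 lies within the scatter, so the two compounds cannot be told apart on these data; both sit at weak toxicity.

Compound 3 `ClCc1ccc(Cn2cnc3ncnc(Cl)c32)cc1` differs from compound 2 in one place: hydrogen in place of chloro on an aromatic carbon. Within the data shown here, no measured pair shows this kind of change, so there is no step to lean on. Removing a chloro group from compound 2 gives no reason, from what is known here, to expect a gain in toxicity; the step of a 1.7-fold higher number from compound 2 to compound 3 (0.22 log units; within the scatter) is expected to be modest, towards higher numbers, and possibly no larger than the scatter. Compound 3 is therefore expected to give about 9500 nM, within a range from 3500 nM to 30000 nM.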

Compound 3, concentration lethal to 50% of the cells: 46800 nM
For compound 3 the middle estimate is 4.9-fold (0.69 log units) below the measured one; the measured number lies above the stated range.
By their numbers in this assay, from the lowest: compounds 2 and 1 (each within the scatter of the next); then compound 3.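

Within this assay, replacing the chloro group with hydrogen on the aromatic carbon between two ring nitrogen atoms gives an 8.1-fold higher number from compound 2 to compound 3 (0.91 log units; beyond the scatter), a step beyond the scatter. This position therefore matters: in this pair, keeping the chloro group there goes with the higher toxicity in this test. Compounds 1 and 2 could not show this, as neither pair member lacks that chloro group, and no measurement here explains the size of the step.

As far as these compounds go, whether an amine or a methoxy group on this same carbon would stay close to compound 2 or fall towards compound 3 remains open. Also open, from the compounds shown here alone, is whether the same swap would give a similar step with the chloromethyl group placed as in compound 1, and what replacing the remaining chloro group would do.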